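The source may hold more compounds than are shown below. What is called first, only, known or untested is meant among the compounds shown, and "the series" means these compounds.

In a physicochemical assay for solubility (on this read-out lower numbers stand for lower solubility and higher numbers for higher solubility), compound 1 `CCCS(=O)(=O)N1CCC(CNC(=O)c2ccc(F)cc2C(F)(F)F)(C(=O)N2CCOCC2)CC1` gives 10000 ug/mL and compound 2 `CCCS(=O)(=O)N1CCC(CNC(=O)c2ccccc2OC(F)(F)F)(C(=O)N2CCOCC2)CC1` gives 10000 ug/mL, so compound 2 stands level with compound 1. Compound 3 `CCCS(=O)(=O)N1CCC(CNC(=O)c2c(F)cccc2F)(C(=O)N2CCOCC2)CC1` carries 2,6-difluorophenyl in place of 2-(trifluoromethoxy)phenyl on a carbonyl carbon. Among the measured compounds shown here, the one measured step that bears on this, no change at the digits printed from compound 1 to compound 2 (within the scatter), also exchanged the group on that carbonyl carbon, and it stayed within the scatter. No step beyond the scatter is therefore expected in this assay, and the expected move is no change at the digits printed from compound 2 to compound 3 (within the scatter). Compound 3 is estimated at 10000 ug/mL, with an expected range of 4000 ug/mL to 12000 ug/mL.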

Compound 3, solubility: 10000 ug/mL
The estimate for compound 3 equals the measured number at the digits printed; the range from low to high includes it.
By their numbers in this assay, from the lowest: compounds 1, 2 and 3 (each within the scatter of the next).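

In this assay, among the compounds shown here, 2,6-difluorophenyl on a carbonyl carbon carries neither trifluoromethyl nor trifluoromethoxy, unlike the groups in the earlier compounds, yet the read-out shows no change at the digits printed from compound 2 to compound 3 (within the scatter) and no change at the digits printed from compound 1 to compound 3 (within the scatter). The exchange also removes the hydrogen-bond acceptor counted on 2-(trifluoromethoxy)phenyl, and this too leaves the number unmoved. Nothing measured here explains this constancy.

As far as these compounds go, all three groups at this place are fluorinated phenyls, so the effect of an unfluorinated phenyl, or of a phenyl bearing an amine or a carboxylic acid, remains open. From the compounds shown here alone, the compounds also share one core, so whether these exchanges would stay as flat on another core is unknown.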